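Amine substituent on the piperidine ring of compound 2

This account rests on a few compounds, and the source may have more. Where it says the series, first, only, none or still open, it means among the compounds named here.

Measured so far in a functional assay on HeLa cells for agonist activity at 5-hydroxytryptamine receptor 6 (Homo sapiens), read by cAMP accumulation and immunoassay; a lower number here means that less compound is needed, a higher number that more compound is needed for the effect:
compound 1 `O=S(=O)(c1cccc(F)c1)c1cn(C2CCNC2)c2ncccc12`, 278 nM
compound 2 `CN1CCCC(n2cc(S(=O)(=O)c3cccc(F)c3)c3cccnc32)C1`, 306 nM

Going by the values given here, compound 2 is one of only two measured members. Its value and that of compound 1 lie within the usual scatter of each other, so neither can be ranked against the other on these numbers; the series has so far given a narrow band of results.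

Compound 3 `CC(C)N1CCCC(n2cc(S(=O)(=O)c3cccc(F)c3)c3cccnc32)C1` differs from compound 2 in one place: isopropyl in place of methyl on an amine nitrogen in a ring. Among the compounds with values here, the only measured step, a 1.1-fold higher number from compound 1 to compound 2 (0.04 log units; within the scatter), concerns the ring that carries the amine nitrogen and its substituent, not the substituent on that nitrogen itself, and it stayed within the scatter. Within the data shown here, no measured pair shows the effect of enlarging the alkyl group on that nitrogen. Among the measured compounds shown here, with the one available step flat, the expectation for compound 3 in this assay is a step of the size a 1.1-fold higher number from compound 2 to compound 3 (0.03 log units; within the scatter), that is, none beyond the scatter, with a wide range because the change is not covered by any measured pair. Compound 3 is therefore estimated at 330 nM, between 140 nM and 800 nM.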

Compound 3, half-maximal effective concentration: 172 nM
For compound 3 the middle estimate is 1.9-fold (0.28 log units) above the measured one, and the stated range covers the measured number.
By their numbers in this assay, from the lowest: compounds 3, 1 and 2 (each within the scatter of the next).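

In this assay, the amine nitrogen of the six-membered ring now has a step of its own: isopropyl in place of methyl gives a 1.8-fold lower number from compound 2 to compound 3 (0.25 log units; within the scatter) and this stays within the scatter, so the substituent on this nitrogen can go from one carbon to three with no readable effect on the number. Taking ring and nitrogen substituent together, 1-isopropylpiperidin-3-yl in place of pyrrolidin-3-yl on the aromatic nitrogen gives a 1.6-fold lower number from compound 1 to compound 3 (0.21 log units; within the scatter) and this too stays within the scatter, so all three compounds remain one narrow band. No available evidence bears on why these steps are small.

Open, from the compounds shown here alone, is whether a benzyl or cyclohexyl group on that amine nitrogen, or a hydrogen in place of the alkyl group on the six-membered ring, would move the number beyond the scatter. Also open, going by these compounds, is whether a carboxylic acid or a nitrile elsewhere on the shared core would separate members in a way that these alkyl and ring changes do not.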